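Thiophene for Pyridine on a Shared Core

The compounds below may be only part of what the source reports. "The series", "measured", "known", "first", "only" and "open" are said of these compounds alone.

compound 1 `Oc1ccc(-c2cc(-c3ccccn3)nc(-c3ccccc3Cl)c2)cc1`: 5.2%
compound 2 `Oc1ccc(-c2cc(-c3ccc(Cl)cc3)nc(-c3cccnc3)c2)cc1`: 18.8%

In an assay on isolated protein for inhibition of DNA topoisomerase 1 (Homo sapiens), with a stated time of 30 min, tested at 100 uM (a higher number here means a stronger effect of the compound at the concentration tested, a lower number a weaker effect), compound 1 gives 5.2%, the lowest of the two numbers shown. Compound 2 gives 18.8%, a number higher by more than the usual scatter. Compound 3 `Oc1ccc(-c2cc(-c3cccs3)nc(-c3ccccc3Cl)c2)cc1` differs from compound 1 in one place: thiophen-2-yl in place of pyridin-2-yl on an aromatic carbon. Going by the values given here, no pair of measured compounds shows this change, so no measured step guides the expectation. The step expected in this assay from compound 1 to compound 3 is a number 4.8 percentage points higher from compound 1 to compound 3 (within the scatter), small and within the scatter. Compound 3 is therefore estimated at 10%, with a range from 0% to 28%.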

Compound 3, a percentage reported as inhibition, at one concentration (the size of the read-out at that concentration, not a potency): 2.2%
The estimate for compound 3 lay 7.8 percentage points above the measured number; the measured number falls inside the stated range.
By their numbers in this assay, from the lowest: compounds 3 and 1 (each within the scatter of the next); then compound 2.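

With thiophen-2-yl in place of pyridin-2-yl next to the ring nitrogen, this assay gives a number 3 percentage points lower from compound 1 to compound 3 (within the scatter). At this position, on the core of compound 1, exchanging the six-membered aromatic ring for the five-membered one therefore leaves the read-out unchanged within the scatter. Nothing measured here offers an explanation for this result. Going by these compounds, it remains open whether a group of another kind at this position, such as an aminomethyl group or a carboxylic acid, would change the read-out. Compound 2 differs from compound 1 in more than one place, so its number says nothing about this position alone.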